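Chain extension on an amino alcohol: toward compound 4

The source may hold more compounds than are shown below. What is called first, only, known or untested is meant among the compounds shown, and "the series" means these compounds.

Measured so far in a physicochemical assay for lipophilicity; on this read-out lower numbers stand for lower lipophilicity and higher numbers for higher lipophilicity:
compound 1, `CCCCCCCCCCCCNCCN`: 4.69
compound 2, `CCCCCCCCC(O)CNCCO`: 2.14
compound 3, `CCCCCCCCNCCO`: 2.55

Compound 2 stands lowest of the three numbers. Its nearest neighbour is compound 3, which sits higher by a margin beyond the scatter, and compound 1 stands far above it, again beyond the scatter. For the measured compounds named here, compound 1, with the longest saturated chain of the three, also gives the highest number in this assay, and compound 3, with the shorter chain, lies between; no compound here goes against that ordering, though with three members it is no more than a note.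

The unmeasured compound 4, `CCCCCCCCCCCCC(O)CNCCO`, follows from compound 2 by one change: butyl in place of hydrogen on a saturated chain carbon, nine bonds along the chain from an oxygen on a saturated carbon. Nothing else moves; the hydroxyl on the chain, the secondary amine and the hydroxyethyl end all remain.

Going by the values given here, no step between measured compounds with exactly this change is on hand. What the series does show is that compound 1 at 4.69 stands well above compound 3 at 2.55, and that longer chains here go with higher numbers. For compound 4 an upward step of a number 1.96 log units higher from compound 2 to compound 4 (beyond the scatter) in this assay is expected, clearly beyond the scatter. Compound 4 is estimated at 4.1, with a range from 3.5 to 4.7.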

Compound 4, partition coefficient: 4.69
Compound 4: middle estimate off by 0.59 log units, on the low side; low and high end bracket the measured number.
By their numbers in this assay, from the lowest: compound 2; then compound 3; then compounds 1 and 4 (each within the scatter of the next).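

In this assay, for the compounds shown here, butyl in place of hydrogen on a saturated chain carbon, nine bonds along the chain from an oxygen on a saturated carbon, gives a number 2.55 log units higher from compound 2 to compound 4 (beyond the scatter), a large step and the only one here between two compounds that differ in a single place. The earlier compounds shown here offered no such pair, so the note on chain length now has one direct comparison behind it, with the hydroxyl on the chain, the secondary amine and the hydroxyethyl end all unchanged. Nothing on hand accounts for the size of this step.

On these data alone, whether a longer chain in place of butyl would extend the step in this assay or level it off remains open. Also open, as far as these compounds go, is how an amine or a carboxylic acid in place of butyl would read, and whether the same butyl change gives a step of similar size on a chain without the hydroxyl.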